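The compounds below may be only part of what the source reports. "The series", "measured", "known", "first", "only" and "open" are said of these compounds alone.

Measured compounds:

Compound 1, `CCOC(=O)c1cnc(SC)nc1NN1C(=O)C=C(C)C1=O`, in a functional assay on Jurkat cells for inhibition of nuclear factor NF-kappa-B complex (Homo sapiens) (a higher number here means a weaker inhibitor, a lower number a stronger inhibitor), compound 1 gives 200 nM.
Compound 2, `CCOC(=O)c1cnc(-n2nc(C)cc2C)nc1NN1C(=O)C=C(C)C1=O`, in this assay compound 2 gives 10000 nM.

Compound 2 stands with the highest number of the two measured; its nearest neighbour is compound 1, and the step of a 50-fold higher number from compound 1 to compound 2 (1.70 log units; beyond the scatter) separates them. That step is the only one measured so far, and it shows that exchanging the group on this aromatic carbon can move the number a long way.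

Compound 3, `CCOC(=O)c1cnc(-c2ccc(F)cc2)nc1NN1C(=O)C=C(C)C1=O`, has not yet been measured. It differs from compound 2 by 4-fluorophenyl in place of 3,5-dimethyl-1H-pyrazol-1-yl on an aromatic carbon. Among the compounds with values here, no measured step covers this exchange directly: the one step available, a 50-fold higher number from compound 1 to compound 2 (1.70 log units; beyond the scatter), tells only that the site is sensitive, not in which direction a 4-fluorophenyl group will move the number. Since compound 2 already holds the highest number measured, and since compound 1 shows that a different group at this site gives 200 nM, a move toward lower numbers is considered somewhat more likely than a further rise, but with wide uncertainty. The expected step is a 3.3-fold lower number from compound 2 to compound 3 (0.52 log units; beyond the scatter). Compound 3 is therefore estimated at 3000 nM, in a range from 500 nM to 20000 nM.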

Compound 3, half-maximal inhibitory concentration: 700 nM
For compound 3 the middle estimate is 4.3-fold (0.63 log units) above the measured one; the measured number falls inside the stated range.
By their numbers in this assay, from the lowest: compound 1; then compound 3; then compound 2.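

In this assay, the site between two ring nitrogen atoms now moves in both directions: putting 4-fluorophenyl in place of 3,5-dimethyl-1H-pyrazol-1-yl gives a 14-fold lower number from compound 2 to compound 3 (1.15 log units; beyond the scatter), although the two groups carry the same count of heavy atoms. The high number of compound 2 is therefore not shared by every aromatic ring at this site, and the exchange of methylsulfanyl for 4-fluorophenyl gives only a 3.5-fold higher number from compound 1 to compound 3 (0.54 log units; beyond the scatter), a modest step that still leaves compound 1 with the lowest number of the three. No independent information is available to explain why these groups differ.

The compounds shown leave open whether the fluorine matters, since a plain phenyl ring is not among them, and whether a small amine or a morpholine at this carbon would match or pass methylsulfanyl. They also say nothing about whether the order of these three groups would hold if the ethoxycarbonyl group were replaced by a carboxylic acid or an amide.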